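This account rests on a few compounds, and the source may have more. Where it says the series, first, only, none or still open, it means among the compounds named here.

Measured so far:
compound 1 `COC(=O)c1cccc(Oc2ccc(OC)cc2)c1` — > 20000 nM
compound 2 `COC(=O)c1cccc(Oc2ccc(OC)c(F)c2)c1` — > 20000 nM
compound 3 `CCOC(=O)c1ccc(Oc2ccc(OC)cc2)cc1` — > 20000 nM

In a functional assay on HL-60 cells (Homo sapiens) for antiproliferative activity (on this read-out lower numbers stand for stronger inhibition and higher numbers for weaker inhibition), compound 1 gives only a limit of the assay, > 20000 nM. Compound 2 likewise gives only a limit, > 20000 nM. Compound 3 too gives only a limit, > 20000 nM. The change from compound 1 to compound 2 is fluoro in place of hydrogen on an aromatic carbon; the step that the two limits leave unreadable from compound 1 to compound 2 cannot be read because both ends sit at the limit of > 20000 nM in this assay, at which 3 of the 3 values shown sit. Compound 4 `CCOC(=O)c1ccc(Oc2ccc(OC)c(F)c2)cc1` is not yet measured. It differs from compound 3 by fluoro in place of hydrogen on an aromatic carbon, the same change at the same kind of place; the difference between the two cores of compound 1 and compound 3 is not broken down here. For compound 4 in this assay a step that the limit leaves unreadable from compound 3 to compound 4 is expected, resting on compound 3 sitting at the limit of > 20000 nM in this assay, at which 3 of the 3 values shown sit, and on the same change leaving compound 2 there. The estimate for compound 4 is 30000 nM, with a range from 12000 nM to 100000 nM.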

Compound 4, half-maximal inhibitory concentration: 3500 nM
Estimate against measurement, compound 4: 8.6-fold (0.93 log units) above; the measured number lies below the stated range.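

In this assay, fluoro in place of hydrogen on an aromatic carbon, ortho to a methoxy group, gives an at least 5.7-fold lower number from compound 3 to compound 4 (0.75 log units; beyond the scatter), so on this core the change is beyond the scatter. On the core of compound 1 the same change leads to compound 2, which gives only a limit of the assay, > 20000 nM, and the step there cannot be read. The result therefore neither shows that the change carries from one core to the other nor shows that it fails to, and the full size of the readable step stays open because compound 3 also sits at the limit: the limit of > 20000 nM in this assay, at which 3 of the 4 values shown sit.

On these data alone, whether a carboxylic acid in place of the ethyl ester of compound 4 would keep its value stays open. So does the effect of an amine in place of the methoxy group.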